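A cyclohexyl group on compound 1

This account rests on a few compounds, and the source may have more. Where it says the series, first, only, none or still open, it means among the compounds named here.

Values in an ADME assay on Vero cells (Chlorocebus sabaeus) for cytotoxicity, read by MTT assay, with a stated time of 96 h (a lower number here means that less compound is tolerated, a higher number that more compound is tolerated), follow:
Compound 1 `C/C(=N\NC(N)=O)c1ccc2[nH]c(-c3ccc(Cl)cc3)nc2c1` gives > 100000 nM as a limit of the assay
Compound 2 `COc1ccc(-c2nc3cc(/C(C)=N/NC(N)=O)ccc3[nH]2)cc1` gives "not determined" (no result reported) in this record
Compound 3 `C/C(=N\NC(N)=S)c1ccc2[nH]c(-c3ccc(Cl)cc3)nc2c1` gives > 100000 nM as a limit of the assay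

Compound 1 stands at the limit of > 100000 nM in this assay, at which 2 of the 3 values shown sit, and so offers a limit, not an exact starting number. Compound 4 `C/C(=N\NC(N)=O)c1ccc2c(c1)nc(-c1ccc(Cl)cc1)n2C1CCCCC1` differs from it by cyclohexyl in place of hydrogen on an aromatic nitrogen. Among the compounds with values here, the one measured step, a step that the two limits leave unreadable from compound 1 to compound 3, lies elsewhere in the molecule and gives no size for this change. The expected step, an at least 2.0-fold lower number from compound 1 to compound 4 (0.30 log units; that floor lies within the scatter), is a modest, loosely held estimate toward less compound tolerated in this assay and may not clear the limit. Compound 4 is expected at 50000 nM (estimated range 12000 nM to 150000 nM).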

Compound 4, half-maximal cytotoxic concentration: > 100000 nM
Compound 4: a limit, no number (the forecaster's own chance of this, stated with the estimate: 45%); at least 2.0-fold (0.30 log units) between middle value and limit.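

Compound 4 gives > 100000 nM, a limit and not a number, and compound 1 also stands at a limit, so no step between them can be read: the limit of > 100000 nM in this assay, at which 3 of the 4 values shown sit.

The compounds shown leave open how large the change from cyclohexyl in place of hydrogen on an aromatic nitrogen is in this assay.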